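The compounds below may be only part of what the source reports. "The series", "measured", "known", "first", "only" and "open" are said of these compounds alone.

Compound 3 `CN(C)c1cc2[nH]c(C3CCCCC3)nc2cc1NC(=O)c1ccco1` carries a furan-2-yl on a carbonyl carbon whose other neighbour is an amide-type nitrogen. In an ADME assay on Vero cells (Chlorocebus sabaeus) for cytotoxicity, read by resazurin assay, with a stated time of 3 days (on this read-out lower numbers stand for stronger inhibition and higher numbers for weaker inhibition), compound 3 gives > 100 ug/mL, which is a limit of the assay rather than a number. Compound 1 `CN(C)c1cc2[nH]c(C3CCCCC3)nc2cc1NC(=O)c1ccccc1` has a phenyl in that place, and in this assay compound 1 gives > 100 ug/mL, again only a limit. Compound 2 `CN(C)c1cc2[nH]c(C3CCCCC3)nc2cc1NC(=O)OCc1ccccc1` has a benzyloxy there, and in this assay compound 2 gives > 100 ug/mL, also a limit. Because every value sits at the limit of > 100 ug/mL in this assay, at which 3 of the 3 values shown sit, the steps a step that the two limits leave unreadable from compound 1 to compound 3, a step that the two limits leave unreadable from compound 2 to compound 3 and a step that the two limits leave unreadable from compound 1 to compound 2 cannot be given a size. Compound 4 `Cc1ccc(C(=O)Nc2cc3nc(C4CCCCC4)[nH]c3cc2N(C)C)cc1` differs from compound 3 by 4-methylphenyl in place of furan-2-yl on a carbonyl carbon. Among the compounds with values here, the only comparable steps are the three just described, and none of them shows a readable size, so no shift beyond the scatter in either direction is expected. Compound 4 is therefore expected to give about 150 ug/mL in this assay, within a range from 60 ug/mL to 400 ug/mL. This estimate means an expected step that the limit leaves unreadable from compound 3 to compound 4.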

Compound 4, half-maximal inhibitory concentration: > 100 ug/mL
Compound 4 ended at the assay's limit (the forecaster's own chance of this, stated with the estimate: 80%); the middle value is on the limit's open side.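

In this assay, within the data shown here, no step from compound 1, compound 2 or compound 3 to compound 4 can be given a size, because all four compounds end at the same limit: the limit of > 100 ug/mL in this assay, at which 4 of the 4 values shown sit. The compounds shown leave open whether the group on the carbonyl carbon affects cytotoxicity at all.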